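This account rests on a few compounds, and the source may have more. Where it says the series, first, only, none or still open, it means among the compounds named here.

Working notes on the series. Three compounds are in hand: compound 1 `O=C(NC(=S)NNc1ncnc2ccccc12)c1ccc(C(F)(F)F)cc1`, compound 2 `COc1cc2ncnc(NNC(=S)NC(=O)c3ccccc3Cl)c2cc1OC` and compound 3 `O=C(NC(=S)NNc1ncnc2ccccc12)c1ccccc1Cl`. In a functional assay on GLC82 cells (Homo sapiens) for cytotoxicity, read by MTT assay, with a stated time of 72 h (on this read-out higher numbers stand for weaker inhibition and lower numbers for stronger inhibition), compound 1 gives 12200 nM, compound 2 gives 10000 nM and compound 3 gives 10800 nM. The three numbers lie within the scatter of one another, so compound 2 is not separable from compound 1 or compound 3 on these data. The next compound is compound 4 `COc1cc2ncnc(NNC(=S)NC(=O)c3ccccc3F)c2cc1OC`, which differs from compound 2 by fluoro in place of chloro on an aromatic carbon. Among the compounds with values here, no measured pair shows this change, so nothing sets its size; the step from compound 2 to compound 4 in this assay is expected to stay within the scatter, with no direction to call, at no change at the digits printed from compound 2 to compound 4 (within the scatter). Compound 4 is therefore estimated at 10000 nM, with a range from 5000 nM to 20000 nM.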

Compound 4, half-maximal inhibitory concentration: 8640 nM
The estimate for compound 4 lay 1.2-fold (0.06 log units) above the measured number; the range from low to high includes it.
By their numbers in this assay, from the lowest: compounds 4, 2, 3 and 1 (each within the scatter of the next).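

In this assay, within the data shown here, the first measured change at this position, fluoro in place of chloro on an aromatic carbon ortho to a large group, gives a 1.2-fold lower number from compound 2 to compound 4 (0.06 log units; within the scatter). On this read-out, 2-chlorophenyl and 2-fluorophenyl are therefore not separated in this series. No measurement in hand offers an explanation for this result.

As far as these compounds go, whether a different group at this position, such as an amine, a methoxy or a carboxylic acid, would move the number beyond the scatter remains open. So does whether the same halogen exchange would read alike on the core of compound 3.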